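Thioamide in Place of Imidate: Cytotoxicity Expectation

The source may report more compounds than this note shows. Statements on the series, on what has been measured and on what is new or still open speak of the compounds shown alone.

Measured so far in an ADME assay (Fibroblast) for cytotoxicity, with Homo sapiens as the target; on this read-out lower numbers stand for stronger inhibition and higher numbers for weaker inhibition:
Compound 1, `N#Cc1cn(COCCO)c2ncnc(N)c12`, gives > 100000 nM, which is a limit of the assay and not a number.
Compound 2, `COC(=N)c1cn(COCCO)c2ncnc(N)c12`, gives > 100000 nM, again a limit of the assay and not a number.

Compound 2 therefore stands at the limit of > 100000 nM in this assay, at which 2 of the 2 values shown sit, so no numerical position can be given for it. The step that the two limits leave unreadable from compound 1 to compound 2 is one that the two limits leave unreadable. Compound 3, `NC(=S)c1cn(COCCO)c2ncnc(N)c12`, differs from compound 2 by a group of 3 heavy atoms (1 carbon, 1 nitrogen, 1 sulfur; no ring) in place of a group of 4 heavy atoms (2 carbon, 1 nitrogen, 1 oxygen; no ring), on an aromatic carbon. Among the measured compounds shown here, no measured step shows what such a change does in this assay, because a step that the two limits leave unreadable from compound 1 to compound 2 has no readable size. For the measured compounds named here, the only evidence is that both values sit at the limit of > 100000 nM in this assay, at which 2 of the 2 values shown sit, and a step of this kind gives no ground to expect compound 3 to leave that limit. Compound 3 is therefore expected to show 100000 nM, within the range 40000 nM to 300000 nM, which is the expected step of a number no higher from compound 2 to compound 3 (the limit leaves the size open).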

Compound 3, half-maximal inhibitory concentration: 100000 nM
Compound 3: the middle estimate sits on the measured number at the digits printed; measured number inside the range.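

In this assay compound 3, which carries a thioamide at this aromatic carbon, gives 100000 nM as a number, the first in this series that is not a limit of the assay. On these data alone, the change to the thioamide reads as a number no higher from compound 2 to compound 3 (the limit leaves the size open), and as a number no higher from compound 1 to compound 3 (the limit leaves the size open): each step starts from a limit, so the size of the change from nitrile or imidate to thioamide stays open. Most of the series still sits at the edge of what this read-out can report: the limit of > 100000 nM in this assay, at which 2 of the 3 values shown sit.

The compounds shown leave open what an amine, a carboxylic acid or a plain amide would give on this aromatic carbon. They also leave open whether a longer chain in place of the (2-hydroxyethoxy)methyl group would shift the value of the thioamide.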